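The compounds below may be only part of what the source reports. "The series", "measured", "known", "first", "only" and "open" are said of these compounds alone.

In a functional assay on A549 cells (Homo sapiens) for cytotoxicity, read by MTT assay, with a stated time of 48 h (on this read-out lower numbers stand for stronger inhibition and higher numbers for weaker inhibition), compound 2 `CC(CO)NCCOc1c(O)cc(O)c2c(=O)cc(-c3ccccc3)oc12` offers no number: its entry reads "not determined" (no result reported), so the step to compound 4 `O=c1cc(-c2ccccc2)oc2c(OCCCN3CCCC3)c(O)cc(O)c12` has no measured starting point. The structural change is (pyrrolidin-1-yl)methyl in place of (1-(hydroxymethyl)ethyl)amino on a saturated chain carbon, two bonds along the chain from an oxygen on an aromatic ring. Among the measured compounds, compound 1 `COc1c(OCCCCN2CCNCC2)cc(O)c2c(=O)cc(-c3ccccc3)oc12` gives 1740 nM and compound 3 `COc1c(OCCCCN2CCCC2)cc(O)c2c(=O)cc(-c3ccccc3)oc12` gives 1530 nM. For the measured compounds named here, the only measured step, a 1.1-fold lower number from compound 1 to compound 3 (0.06 log units; within the scatter), swaps piperazin-1-yl for pyrrolidin-1-yl and bears only loosely on this change. With no value for compound 2, no size or direction can be set for the step in this assay. The nearest guide is compound 3 at 1530 nM, which also carries pyrrolidin-1-yl but differs from compound 4 elsewhere, so the range stays wide. Compound 4 is expected near 2000 nM, with an estimated range of 600 nM to 7000 nM.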

Compound 4, half-maximal inhibitory concentration: > 100000 nM
Compound 4: only a limit was reported; the forecaster's own chance of this, stated with the estimate: 10%; middle value at least 50-fold (1.69 log units) away from the limit.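

Compound 2 has no result and compound 4 has only a limit, > 100000 nM, so no new step can be read. From the compounds shown here alone, how far 3-(pyrrolidin-1-yl)propoxy in place of 2-((1-(hydroxymethyl)ethyl)amino)ethoxy shifts the read-out stays open.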